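Swapping the hydroxy of compound 1 for a methylpiperazine

This account rests on a few compounds, and the source may have more. Where it says the series, first, only, none or still open, it means among the compounds named here.

Measured so far, in a functional assay on SK-MEL-28 cells (Homo sapiens) for cytotoxicity, read by MTT assay, with a stated time of 3 days; on this read-out lower numbers stand for stronger inhibition and higher numbers for weaker inhibition:
Compound 1, `N#Cc1c(O)nc(SCc2nc3ccccc3[nH]2)nc1-c1ccccc1`, gives 7.7 nM.
Compound 2, `N#Cc1c(Nc2ccccn2)nc(SCc2nc3ccccc3[nH]2)nc1-c1ccccc1`, gives 8.9 nM.
Compound 3, `N#Cc1c(NNC(N)=S)nc(SCc2nc3ccccc3[nH]2)nc1-c1ccccc1`, gives 3.2 nM.

Compound 1 stands second highest of the three numbers; its nearest neighbour is compound 2 and its furthest is compound 3. The steps away from it were a 1.2-fold higher number from compound 1 to compound 2 (0.06 log units; within the scatter) and a 2.4-fold lower number from compound 1 to compound 3 (0.38 log units; beyond the scatter).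

Compound 4, `CN1CCN(c2nc(SCc3nc4ccccc4[nH]3)nc(-c3ccccc3)c2C#N)CC1`, is not yet measured. It differs from compound 1 as follows: 4-methylpiperazin-1-yl in place of hydroxy on an aromatic carbon. Going by the values given here, no measured pair shows this exact change. The closest comparison is the step that also swapped the hydroxy of compound 1 for a nitrogen-linked group, a 1.2-fold higher number from compound 1 to compound 2 (0.06 log units; within the scatter), which stayed within the scatter. On that basis no step beyond the scatter is expected; the estimated step is a 1.2-fold higher number from compound 1 to compound 4 (0.07 log units; within the scatter). Compound 4 is therefore expected to give 9 nM, with a range from 3 nM to 30 nM.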

Compound 4, half-maximal inhibitory concentration: 20 nM
The estimate for compound 4 lay 2.2-fold (0.35 log units) below the measured number; measured number inside the range.
By their numbers in this assay, from the lowest: compound 3; then compounds 1 and 2 (each within the scatter of the next); then compound 4.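

In this assay, this position turns out not to accept every nitrogen-linked group equally: 4-methylpiperazin-1-yl gives a 2.6-fold higher number from compound 1 to compound 4 (0.41 log units; beyond the scatter), and it is the only replacement for hydroxy here that raises the number beyond the scatter. The same group also separates from the other two nitrogen-linked groups, with a 2.2-fold higher number from compound 2 to compound 4 (0.35 log units; beyond the scatter) and a 6.3-fold higher number from compound 3 to compound 4 (0.80 log units; beyond the scatter), so the identity of the group matters at this position even though the step from hydroxy to (pyridin-2-yl)amino stayed within the scatter. Nothing measured here explains why the number rises with this group.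

The compounds shown leave open which part of the entering group goes with the rise: the six-membered non-aromatic ring, the methyl, or the 0 hydrogen-bond donors it carries. A piperazine without the methyl, a morpholine or an open-chain dimethylamino group at this position would help to separate these.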